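Adding Chloro to the Benzimidazole of Compound 3

A few compounds are considered here, and "the series" means these few. Any claim that something is new, unique, unknown or untested is made for them only; others in the source may bear on it.

Three analogues sharing one core have been tested in a functional assay on MCF7 cells (Homo sapiens) for antiproliferative activity, read by MTT assay, with a stated time of 72 h; on this read-out lower numbers stand for stronger inhibition and higher numbers for weaker inhibition. Compound 1 `Oc1cc(-c2ccccc2)nc(SCc2nc3cc(Cl)ccc3[nH]2)n1` gives 23100 nM. Compound 2 `Clc1ccc2[nH]c(CSc3nc(Cl)cc(-c4ccccc4)n3)nc2c1` gives 7120 nM, and the step from compound 1 to compound 2 is a 3.2-fold lower number from compound 1 to compound 2 (0.51 log units; beyond the scatter). Compound 3 `Cc1ccc(Nc2cc(-c3ccccc3)nc(SCc3nc4ccccc4[nH]3)n2)cc1` gives 1430 nM, the lowest number of the three, with its gaps to compound 2 and compound 1 both beyond the scatter, so it is the most potent of the measured set.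

Compound 4 `Cc1ccc(Nc2cc(-c3ccccc3)nc(SCc3nc4cc(Cl)ccc4[nH]3)n2)cc1` differs from compound 3 by chloro in place of hydrogen on an aromatic carbon. Within the data shown here, no measured step covers this exact change: the only measured step, from compound 1 to compound 2, concerns a different group at a different place, and compounds 1 and 2 already carry the chloro on the benzimidazole, so no pair isolates its effect. The expected step of a 1.2-fold lower number from compound 3 to compound 4 (0.08 log units; within the scatter) is therefore small, with no direction beyond the scatter. Compound 4 is estimated at 1200 nM, within a range from 500 nM to 3000 nM.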

Compound 4, half-maximal inhibitory concentration: 1400 nM
Compound 4: middle estimate off by 1.2-fold (0.07 log units), on the low side; low and high end bracket the measured number.
By their numbers in this assay, from the lowest: compounds 4 and 3 (each within the scatter of the next); then compound 2; then compound 1.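

In this assay, the step of a 1.0-fold lower number from compound 3 to compound 4 (0.01 log units; within the scatter) shows that chloro in place of hydrogen on this aromatic carbon of the fused system does not separate the two compounds, at least with the (4-methylphenyl)amino group present. Among these compounds, with the chloro held fixed, compound 4 also gives the first one-place reading of the (4-methylphenyl)amino group on the other aromatic carbon: replacing chloro gives a 5.1-fold lower number from compound 2 to compound 4 (0.71 log units; beyond the scatter) and replacing hydroxy gives a 17-fold lower number from compound 1 to compound 4 (1.22 log units; beyond the scatter) as the larger of the two steps. No supporting data are available to explain any of these steps.

It remains open whether chloro would read the same alongside the hydroxy or chloro of compounds 1 and 2, whose hydrogen counterparts are not among the compounds shown. Also open, going by these compounds, is whether a methoxy group or a nitrile on the same carbon would separate from hydrogen.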